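The compounds below may be only part of what the source reports. "The series", "measured", "known", "first", "only" and "open" are said of these compounds alone.

Compound 1 `Brc1cn2ccnc2c(-c2ccc3ncn(C4CCCCC4)c3c2)n1`: 44.4%
Compound 2 `Clc1ccc(-c2cn3ccnc3c(-c3ccc4ncn(C5CCCCC5)c4c3)n2)cc1`: 10.6%

In a functional assay on MDA-MB-468 cells (Homo sapiens) for inhibition, read by sulforhodamine B assay, with a stated time of 48 h, tested at 10 uM (a lower number here means less inhibition, a higher number more inhibition at the concentration tested (going by the name of the read-out)), compound 1 gives 44.4% and compound 2 gives 10.6%; compound 2 stands lowest of the two. Within the data shown here, the only measured step, a number 33.8 percentage points lower from compound 1 to compound 2 (beyond the scatter), exchanged bromo for an aromatic ring at the same place. Compound 3 `c1csc(-c2cn3ccnc3c(-c3ccc4ncn(C5CCCCC5)c4c3)n2)c1` differs from compound 2 by thiophen-2-yl in place of 4-chlorophenyl on an aromatic carbon. Here one aromatic ring replaces another, so that step gives only a loose guide; no step beyond the scatter is expected, a number 6.4 percentage points higher from compound 2 to compound 3 (within the scatter). Compound 3 is estimated at 17%, within 0% to 40%.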

Compound 3, a percentage reported as inhibition, at one concentration (the size of the read-out at that concentration, not a potency): 15.1%
Compound 3: middle estimate off by 1.9 percentage points, on the high side; the range from low to high includes it.
By their numbers in this assay, from the lowest: compounds 2 and 3 (each within the scatter of the next); then compound 1.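

Thiophen-2-yl in place of 4-chlorophenyl gives a number 4.5 percentage points higher from compound 2 to compound 3 (within the scatter) in this assay, so at this position the five-membered aromatic ring with one hetero atom and the six-membered carbon ring cannot be told apart. Against bromo, thiophen-2-yl gives a number 29.3 percentage points lower from compound 1 to compound 3 (beyond the scatter), so the lower number seen with 4-chlorophenyl recurs with a second aromatic ring and is not peculiar to that one group. Going by these compounds, whether an aromatic ring as such goes with the lower numbers stays open, and an amine or a short alkyl chain on this carbon would test that. No measured evidence accounts for the difference from bromo.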